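Aryl groups on the ring amide nitrogen: the step to compound 4

This account rests on a few compounds, and the source may have more. Where it says the series, first, only, none or still open, it means among the compounds named here.

Compound 1, `CC(C)[C@@H]1CC[C@@H](C)C[C@@]12N(C)C(=O)[C@@H]1[C@H]3C(=O)N(C)C(=O)[C@H]3ON12`: in a functional assay, read by spectrophotometry, with a stated time of 2 h, tested at 1 mg/mL (on this read-out higher numbers stand for a stronger effect at the one concentration tested and lower numbers for a weaker effect), compound 1 gives 47.7%.
Compound 2, `CC(C)[C@@H]1CC[C@@H](C)C[C@@]12N(C)C(=O)[C@@H]1[C@H]3C(=O)N(c4ccc(Cl)cc4)C(=O)[C@H]3ON12`: compound 2 gives 53.7%.
Compound 3, `COc1ccc(N2C(=O)[C@H]3[C@H](ON4[C@@H]3C(=O)N(C)[C@@]43C[C@H](C)CC[C@H]3C(C)C)C2=O)cc1`: compound 3 gives 50%.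

Compound 3 holds the second highest of the three numbers, yet both its neighbours sit within the scatter of it: a number 2.3 percentage points higher from compound 1 to compound 3 (within the scatter) and a number 3.7 percentage points lower from compound 2 to compound 3 (within the scatter). The remaining measured step, a number 6 percentage points higher from compound 1 to compound 2 (within the scatter), is also within the scatter. Every exchange so far has been made on the same amide-type nitrogen in a ring, or on the aryl group carried there, and none has moved the read-out beyond the noise.

Compound 4, `Cc1cccc(N2C(=O)[C@H]3[C@H](ON4[C@@H]3C(=O)N(C)[C@@]43C[C@H](C)CC[C@H]3C(C)C)C2=O)c1`, continues this line. The change from compound 3 is 3-methylphenyl in place of 4-methoxyphenyl on an amide-type nitrogen in a ring. All three measured steps bear on it, since each concerns the group on this nitrogen, and each was small. The expected step of no change at the digits printed from compound 3 to compound 4 (within the scatter) is therefore none beyond the scatter. Compound 4 is estimated to give about 50%, within a range from 40% to 60%.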

Compound 4, a percentage reported as activity, at one concentration (the size of the read-out at that concentration, not a potency): 39%
Beside the measured number, compound 4's estimate is 11 percentage points above it; measured number outside the range, below it.
By their numbers in this assay, from the lowest: compounds 4, 1, 3 and 2 (each within the scatter of the next, the first and the last beyond it).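

In this assay, the group on the amide-type nitrogen in a ring can move the read-out beyond the scatter: 3-methylphenyl in place of 4-methoxyphenyl gives a number 11 percentage points lower from compound 3 to compound 4 (beyond the scatter), and 3-methylphenyl in place of 4-chlorophenyl gives a number 14.7 percentage points lower from compound 2 to compound 4 (beyond the scatter). The three aryl groups are therefore not interchangeable here, although 3-methylphenyl in place of methyl remains a number 8.7 percentage points lower from compound 1 to compound 4 (within the scatter), so no aryl group shown separates from methyl. Nothing available explains the difference among the aryl groups.

The step from compound 3 to compound 4 exchanges the substituent on the phenyl ring and also its place on that ring, and the compounds shown do not separate these two changes. On these data alone, how an unsubstituted phenyl, a benzyl group or a phenyl ring carrying a carboxylic acid would read at this nitrogen remains open.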